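The source may hold more compounds than are shown below. What is called first, only, known or untested is meant among the compounds shown, and "the series" means these compounds.

In a functional assay on HT-29 cells (Homo sapiens) for inhibition (a higher number here means a weaker inhibitor, a lower number a stronger inhibitor), compound 3 (`O=S(=O)(c1ccccc1)n1ccc2cc(/C=C\c3ccc4ccccc4c3)ccc21`) gives > 5000 nM, which is a limit and not a number. Compound 2 (`O=S(=O)(c1ccccc1)n1ccc2cc(/C=C/c3ccc4ccccc4c3)ccc21`) gives > 5000 nM, also a limit. Compound 1 (`C(=C\c1ccc2ccccc2c1)\c1ccoc1`) gives > 5000 nM, again a limit. Within the data shown here, the series so far therefore rests on (the limit of > 5000 nM in this assay, at which 3 of the 3 values shown sit). Among the measured compounds shown here, the one measured step, a step that the two limits leave unreadable from compound 2 to compound 3, concerns (the fact that compounds 2 and 3 differ only in the configuration as drawn), and it offers no size to carry over.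

Compound 4 (`Cn1ccc2cc(/C=C\c3ccc4ccccc4c3)ccc21`) differs by methyl in place of phenylsulfonyl on an aromatic nitrogen. For the measured compounds named here, no measured step involves this change, so the data set neither size nor direction, and another reading at the limit remains likely in this assay. The expected step, held only loosely, is a number no higher from compound 3 to compound 4 (the limit leaves the size open). Compound 4 is estimated at 5000 nM, with an expected range from 500 nM to 20000 nM.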

Compound 4, half-maximal inhibitory concentration: > 5000 nM
Compound 4 was reported as a limit; the forecaster's own chance of this, stated with the estimate: 60%; the middle value lies on the limit itself.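

Compound 4 gives > 5000 nM in this assay, which is a limit, so the change from compound 3 to compound 4 yields no readable step. The compounds shown leave open how strongly any of them inhibits.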